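A few compounds are considered here, and "the series" means these few. Any claim that something is new, unique, unknown or untested is made for them only; others in the source may bear on it.

Compound 2 `Cc1cccc(CCCN2CC=C(CCC(=O)NO)C2=O)c1` gives 2210 nM in a functional assay on MDA-MB-231 cells (Homo sapiens) for inhibition, read by sulforhodamine B assay (on this read-out higher numbers stand for weaker inhibition of growth and lower numbers for stronger inhibition of growth), and stands level with compound 1 `O=C(CCC1=CCN(CCCc2ccc(Br)cc2)C1=O)NO`, which in this assay gives 2210 nM. Compound 3 `Cc1ccc(CCCN2CC=C(CCC(=O)NO)C2=O)cc1` differs from compound 2 only in that (4-methylphenyl in place of 3-methylphenyl on a saturated chain carbon, three bonds along the chain from an amide-type nitrogen in a ring). Going by the values given here, the one step that bears on this change, where another group on the same saturated chain carbon was exchanged, gave no change at the digits printed from compound 1 to compound 2 (within the scatter) in this assay, so no change beyond the scatter is expected here either. Compound 3 is therefore expected to give 2200 nM in this assay, within 1100 nM to 4400 nM, a step of a 1.0-fold lower number from compound 2 to compound 3 (0.00 log units; within the scatter) that is expected to be flat.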

Compound 3, concentration for 50% growth inhibition: 2210 nM
Compound 3: middle estimate off by 1.0-fold (0.00 log units), on the low side; the range from low to high includes it.
By their numbers in this assay, from the lowest: compounds 1, 2 and 3 (each within the scatter of the next).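

Placing 4-methylphenyl in place of 3-methylphenyl brings no change at the digits printed from compound 2 to compound 3 (within the scatter) in this assay, so moving the methyl on this ring does not register in this read-out. Methyl in place of bromo on an aromatic carbon, a direct comparison of these two groups, brings no change at the digits printed from compound 1 to compound 3 (within the scatter). No supporting data offer an explanation for these flat results. Still open, from the compounds shown here alone, is whether a carboxylic acid or an amine on the aromatic ring, or a longer chain in place of the present one, would shift the value beyond the scatter.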